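This account rests on a few compounds, and the source may have more. Where it says the series, first, only, none or still open, it means among the compounds named here.

Of the compounds shown here, three have been measured in an assay on isolated protein for inhibition of annexin A2/S100-A10 (Homo sapiens), with a stated time of 5 min, tested at 50 uM; a lower number here means less inhibition, a higher number more inhibition at the concentration tested (going by the name of the read-out). Compound 1 `Cc1ccc(C(=O)C2=C(O)C(=O)N(CC(C)O)C2c2ccc(C(C)C)cc2)cc1` gives 101%. Compound 2 `Cc1ccc(C(=O)C2=C(O)C(=O)N(CC(C)O)C2c2cccc(C(C)C)c2)cc1`, with 3-isopropylphenyl in place of 4-isopropylphenyl on a saturated ring carbon, gives 100% in this assay, a step of a number 1 percentage points lower from compound 1 to compound 2 (within the scatter). Compound 3 `CCCc1ccc(C2C(C(=O)c3ccc(C)cc3)=C(O)C(=O)N2CC(C)O)cc1`, with propyl in place of isopropyl on an aromatic carbon, gives 97% in this assay. Compound 3 holds the lowest of the three numbers, but the steps of a number 4 percentage points lower from compound 1 to compound 3 (within the scatter) and a number 3 percentage points lower from compound 2 to compound 3 (within the scatter) are both within the scatter, so the three compounds cannot be told apart.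

Compound 4 `Cc1ccc(C(=O)C2=C(O)C(=O)N(CC(C)O)C2c2ccc(OC(F)(F)F)cc2)cc1` is not yet measured; it differs from compound 3 by trifluoromethoxy in place of propyl on an aromatic carbon. Among the measured compounds shown here, the measured steps that bear on this aromatic carbon, a number 4 percentage points lower from compound 1 to compound 3 (within the scatter) and a number 3 percentage points lower from compound 2 to compound 3 (within the scatter), exchange one alkyl group for another and stay within the scatter; no measured step brings in trifluoromethoxy. All three measured numbers sit at the top of the read-out, leaving little room for a rise. The expected step is therefore a number 3 percentage points lower from compound 3 to compound 4 (within the scatter), with no direction beyond the scatter. Compound 4 is estimated at 94%, in the range 72% to 102%.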

Compound 4, a percentage reported as inhibition, at one concentration (the size of the read-out at that concentration, not a potency): 110%
Estimate against measurement, compound 4: 16 percentage points below; the whole stated range lies below it.
By their numbers in this assay, from the lowest: compounds 3, 2, 1 and 4 (each within the scatter of the next, the first and the last beyond it).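

Among the compounds shown here, at this aromatic carbon, para to a large group, trifluoromethoxy in place of propyl gives the first step beyond the scatter in this assay, a number 13 percentage points higher from compound 3 to compound 4 (beyond the scatter), whereas the exchanges among alkyl groups gave none. The separation holds against propyl only: against isopropyl the same group gives a number 9 percentage points higher from compound 1 to compound 4 (within the scatter), so the position accepts trifluoromethoxy without loss of inhibition, but the change cannot be called a gain over the whole alkyl set. Nothing available accounts for the step.

Whether the step follows the oxygen link or the fluorines would take a methoxy or a trifluoromethyl group at this carbon. Also open, going by these compounds, are whether an amine or a carboxylic acid there keeps the inhibition this high, and what potency lies behind these single-concentration numbers.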